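A few compounds are considered here, and "the series" means these few. Any claim that something is new, unique, unknown or untested is made for them only; others in the source may bear on it.

In a functional assay on MKN-45 cells (Homo sapiens) for inhibition, read by CCK-8 assay, with a stated time of 24 h (on this read-out lower numbers stand for stronger inhibition and higher numbers for weaker inhibition), the measured compounds are:

- compound 1 `N#Cc1ccc(-n2cc(-c3ccc(C=C4C(=O)Nc5ccccc54)cc3)nn2)cc1`: > 20000 nM, a limit of the assay and not a number
- compound 2 `N#Cc1ccccc1-n1cc(-c2ccc(C=C3C(=O)Nc4ccc(F)cc43)cc2)nn1`: 15200 nM

Within the data shown here, compound 2, at 15200 nM, holds the only actual number in this assay. Compound 1 is reported only as > 20000 nM, which is a limit.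

Compound 3 `N#Cc1ccc(-n2cc(-c3ccc(C=C4C(=O)Nc5ccc(F)cc54)cc3)nn2)cc1` has the same atoms as compound 2, joined differently: 4-cyanophenyl in place of 2-cyanophenyl on an aromatic nitrogen. Among the measured compounds shown here, no measured step shows what such a move does, so the expectation rests on the values alone. Inhibition by compound 2 at 15200 nM is already weak, and little change is expected: nothing beyond the scatter, with any drift toward weaker inhibition. The expected step is a 1.2-fold higher number from compound 2 to compound 3 (0.07 log units; within the scatter). A reading at the limit of this assay would be no surprise. Compound 3 is estimated at 18000 nM, with an expected range of 9000 nM to 36000 nM.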

Compound 3, half-maximal inhibitory concentration: > 20000 nM
Compound 3 was reported as a limit; the forecaster's own chance of this, stated with the estimate: 45%; middle value at least 1.1-fold (0.04 log units) away from the limit.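

In this assay, 4-cyanophenyl in place of 2-cyanophenyl on the aromatic nitrogen gives an at least 1.3-fold higher number from compound 2 to compound 3 (0.11 log units; that floor lies within the scatter), the first measured view of this change. That step is only a floor, with no upper size, because compound 3 stands at a limit: the limit of > 20000 nM in this assay, at which 2 of the 3 values shown sit.

The step between the two limits, fluoro in place of hydrogen on an aromatic carbon, cannot be read, so the fluoro group's contribution remains unseen. The compounds shown leave open whether an amine or a carboxylic acid in place of the nitrile on this phenyl ring would give a lower number than compound 2 at 15200 nM. They also leave open whether any change at this position would bring inhibition clearly beyond the scatter.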